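A few compounds are considered here, and "the series" means these few. Any claim that something is new, unique, unknown or untested is made for them only; others in the source may bear on it.

The measured compounds in a functional assay on cells (Cancer cell lines, Homo sapiens) for cytotoxicity, read by sulforhodamine B assay, with a stated time of 48 h; on this read-out higher numbers stand for weaker inhibition of growth and lower numbers for stronger inhibition of growth:
compound 1 `Oc1ccc(O)c(-c2cc(-c3ccccc3)nn2-c2ccccc2)c1` gives 100000 nM;
compound 2 `Oc1ccc(O)c(-c2cc(-c3ccc(Cl)cc3)nn2-c2ccccc2)c1` gives 30700 nM;
compound 3 `NS(=O)(=O)c1ccc(-n2nc(-c3ccccc3)cc2-c2cc(O)ccc2O)cc1` gives 100000 nM.

Compound 2 differs from compound 1 by chloro in place of hydrogen on an aromatic carbon, and this change produced a 3.3-fold lower number from compound 1 to compound 2 (0.51 log units; beyond the scatter). Compound 3 differs from compound 1 in its core by sulfamoyl in place of hydrogen on an aromatic carbon, which produced no change at the digits printed from compound 1 to compound 3 (within the scatter). Compound 4 `NS(=O)(=O)c1ccc(-n2nc(-c3ccc(Cl)cc3)cc2-c2cc(O)ccc2O)cc1` has not yet been measured; it differs from compound 3 by chloro in place of hydrogen on an aromatic carbon, the same change as that between compound 1 and compound 2, here made on the core of compound 3. In this assay, among the compounds with values here, the step from compound 3 to compound 4 is expected to be a 2.9-fold lower number from compound 3 to compound 4 (0.46 log units; beyond the scatter), resting on the single measured instance of this change, a 3.3-fold lower number from compound 1 to compound 2 (0.51 log units; beyond the scatter), and on the cores of compound 1 and compound 3 answering alike. The estimate for compound 4 is 35000 nM, expected to fall between 12000 nM and 100000 nM.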

Compound 4, concentration for total growth inhibition: 29800 nM
The estimate for compound 4 lay 1.2-fold (0.07 log units) above the measured number; the range from low to high includes it.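

In this assay, chloro in place of hydrogen gave a 3.4-fold lower number from compound 3 to compound 4 (0.53 log units; beyond the scatter), so this change carried over to the core of compound 3 at about the size it had on the core of compound 1: the same change on two cores in this assay, a 3.3-fold lower number (0.51 log units; beyond the scatter) from compound 1 to compound 2 and a 3.4-fold lower number (0.53 log units; beyond the scatter) from compound 3 to compound 4, 1.0-fold (0.01 log units) apart, within the scatter of two such steps. Sulfamoyl in place of hydrogen, with the chloro already present, gave a 1.0-fold lower number from compound 2 to compound 4 (0.01 log units; within the scatter), which agrees with its step without the chloro: the same change on two cores in this assay, no change at the digits printed (within the scatter) from compound 1 to compound 3 and a 1.0-fold lower number (0.01 log units; within the scatter) from compound 2 to compound 4, 1.0-fold (0.01 log units) apart, within the scatter of two such steps. In these four compounds the two changes therefore behave independently of each other, but this rests on a single pair for each comparison and does not show that the same would hold on other cores or why the numbers behave this way.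

The compounds shown leave open whether a fluoro, a methoxy or an amine in the place of the chloro would move the number as chloro does. They also leave open how a carboxylic acid in the place of the sulfamoyl would read.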